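The source may hold more compounds than are shown below. What is called first, only, known or untested is meant among the compounds shown, and "the series" means these compounds.

Series notes, four compounds on a shared core.

Compound 1 `CCn1c(-c2cnc(C)nc2)nc2c(O[C@H]3CCN(C(=O)C4CC4)C3)ncnc21` carries the cyclopropylcarbonyl amide. In an ADME assay (Canis lupus familiaris, strain Beagle) for metabolic stability (a higher number here means that the compound lasts longer, a lower number that the compound disappears faster), compound 1 gives 1.3 h. Compound 3 `CCn1c(-c2cnc(C)nc2)nc2c(O[C@H]3CCN(C(=O)C4CCC4)C3)ncnc21` differs from it only by cyclobutyl in place of cyclopropyl on a carbonyl carbon. In this assay compound 3 gives 1.1 h; the step of a 1.2-fold lower number from compound 1 to compound 3 (0.07 log units; within the scatter) is within the scatter, so the two numbers are read as the same.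

Compound 2 `CCn1c(-c2cnc(C)nc2)nc2c(N[C@H]3CCN(C(=O)C4CC4)C3)ncnc21` is built on a second core; the difference between the two cores is not broken down here. In this assay, going by the values given here, compound 2 gives 4.7 h, the highest of the three numbers so far, with steps to compound 1 and compound 3 both beyond the scatter.

Compound 4 `CCn1c(-c2cnc(C)nc2)nc2c(N[C@H]3CCN(C(=O)C4CCC4)C3)ncnc21` is the counterpart of compound 3 on the core of compound 2: it differs from compound 2 by cyclobutyl in place of cyclopropyl on a carbonyl carbon. The same change, at a place described in the same words, has been measured once already, from compound 1 to compound 3, and left the half-life essentially where it was.

For compound 4 in this assay the expectation is that the step of a 1.1-fold lower number from compound 2 to compound 4 (0.05 log units; within the scatter) will be of about the same size as a 1.2-fold lower number from compound 1 to compound 3 (0.07 log units; within the scatter), resting on that single earlier pair; one instance is a thin basis, and the wider range reflects that. Compound 4 is therefore estimated at 4.2 h, with the expected range running from 2.4 h to 7.5 h.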

Compound 4, half-life: 1.3 h
Compound 4: middle estimate off by 3.2-fold (0.51 log units), on the high side; measured number outside the range, below it.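

On the core of compound 2, cyclobutyl in place of cyclopropyl on a carbonyl carbon is not a neutral change in this assay: the new step is a 3.6-fold lower number from compound 2 to compound 4 (0.56 log units; beyond the scatter), and the whole of the advantage that compound 2 holds in this read-out is absent from its cyclobutyl counterpart. The size of this change therefore did not carry from one core to the other, and a step read on the core of compound 1 is no safe guide to the same step on the core of compound 2: the same change on two cores in this assay, a 1.2-fold lower number (0.07 log units; within the scatter) from compound 1 to compound 3 and a 3.6-fold lower number (0.56 log units; beyond the scatter) from compound 2 to compound 4, 3.1-fold (0.49 log units) apart, beyond the scatter of two such steps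
This shows that the effect of the swap depends on the core in these two pairs, but it does not show what in the core is responsible or why the half-life responds on one core and not on the other, and with one pair per core it sets no rule for the series.

The compounds shown leave open whether a cyclopentyl or a plain methyl on the same carbonyl carbon would hold the half-life of compound 2 or fall with compound 4. They also leave open whether the gap between the two cores persists for acyl groups carrying an amine or an ether oxygen.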